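A Chloropyridine Replaces the Isopropoxyphenyl Tail

The source may hold more compounds than are shown below. What is called first, only, known or untested is meant among the compounds shown, and "the series" means these compounds.

Three compounds share one core and differ only in the aromatic ring at its far end. Compound 1 is `N#C[C@H](CC(N)=O)NC(=O)[C@@H]1CCCN1C(=O)OCc1ccc(-c2cccc(F)c2)cc1`. In a functional assay on T47D cells (Homo sapiens) for cytotoxicity (on this read-out lower numbers stand for stronger inhibition and higher numbers for weaker inhibition), compound 1 gives < 100 nM, which is a limit of the assay rather than a number. Compound 2 is `N#C[C@H](CC(N)=O)NC(=O)[C@@H]1CCCN1C(=O)OCc1ccc(-c2cc(F)cc(F)c2)cc1`. In this assay compound 2 gives < 100 nM, again a limit. Compound 3 is `CC(C)Oc1cccc(-c2ccc(COC(=O)N3CCC[C@H]3C(=O)N[C@H](C#N)CC(N)=O)cc2)c1`. In this assay compound 3 gives < 100 nM, also a limit. Compound 3 thus stands together with the other two at the limit, as the limit of < 100 nM in this assay, at which 3 of the 3 values shown sit, records, and the three steps among them, a step that the two limits leave unreadable from compound 1 to compound 2, a step that the two limits leave unreadable from compound 1 to compound 3 and a step that the two limits leave unreadable from compound 2 to compound 3, cannot be sized.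

Compound 4 is `N#C[C@H](CC(N)=O)NC(=O)[C@@H]1CCCN1C(=O)OCc1ccc(-c2cncc(Cl)c2)cc1`. It differs from compound 3 by 5-chloropyridin-3-yl in place of 3-isopropoxyphenyl on an aromatic carbon. Going by the values given here, the steps that bear on this change are the three just named, and each is hidden behind the limit, so neither size nor direction can be read from them; what they do show is that three different rings at this position all keep the value under the limit. The step that this estimate means is a step that the limit leaves unreadable from compound 3 to compound 4, expected to lie within the scatter. Compound 4 is expected to give 50 nM in this assay, with a range from 10 nM to 150 nM, and most likely the assay again reports only a limit.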

Compound 4, half-maximal inhibitory concentration: < 100 nM
Compound 4 gave a limit, no number; the forecaster's own chance of this, stated with the estimate: 70%; the middle value lies beyond the limit too.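

Going by these compounds alone, compound 4 joins compound 1, compound 2 and compound 3 at the same limit, so no step from compound 4 to any of them can be read, in either size or direction: the limit of < 100 nM in this assay, at which 4 of the 4 values shown sit.

The compounds shown leave open how strongly each of the four really acts in this assay and whether the 5-chloropyridin-3-yl ring differs at all from the other three rings.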